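Ring size on the urea nitrogen: cyclopentyl to cyclohexyl

The source may report more compounds than this note shows. Statements on the series, on what has been measured and on what is new or still open speak of the compounds shown alone.

Measured compounds:
- compound 1, `COc1cc(NC(C)CCCNC(=O)NCC2CCCCC2)c2ncccc2c1`, 22000 nM
- compound 2, `COc1cc(NC(C)CCCNC(=O)N(C2CCCCC2)C2CCCCC2)c2ncccc2c1`, 15000 nM
- compound 3, `COc1cc(NC(C)CCCNC(=O)NC2CCCC2)c2ncccc2c1`, 41000 nM

In a functional assay on L1210 cells (Mus musculus), read by MTT assay, with a stated time of 72 h (a lower number here means a stronger inhibitor, a higher number a weaker inhibitor), compound 3 gives 41000 nM, the highest of the three numbers. Its nearest neighbour is compound 1; the step of a 1.9-fold higher number from compound 1 to compound 3 (0.27 log units; within the scatter) lies within the scatter, so these two compounds cannot be told apart on the numbers. Compound 2 lies further off, and its gap to compound 3 is beyond the scatter.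

Compound 4, `COc1cc(NC(C)CCCNC(=O)NC2CCCCC2)c2ncccc2c1`, has not yet been measured. It differs from compound 3 in one place: cyclohexyl in place of cyclopentyl on an amide-type nitrogen. Within the data shown here, the only measured step that touches this nitrogen is a 1.9-fold higher number from compound 1 to compound 3 (0.27 log units; within the scatter), which shows that exchanging one carbon ring for another at this position moved the number by less than the scatter. Among the measured compounds shown here, no step in the set directly compares cyclopentyl with cyclohexyl.

The step of a 1.5-fold lower number from compound 3 to compound 4 (0.17 log units; within the scatter) is therefore expected to be small, pointing towards a somewhat lower number but not clearly beyond the scatter. For compound 4 the estimate is 28000 nM, with a range from 12000 nM to 65000 nM.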

Compound 4, half-maximal inhibitory concentration: 23000 nM
Compound 4: middle estimate off by 1.2-fold (0.09 log units), on the high side; measured number inside the range.
By their numbers in this assay, from the lowest: compounds 2, 1, 4 and 3 (each within the scatter of the next, the first and the last beyond it).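

In this assay, among these compounds, the step of a 1.8-fold lower number from compound 3 to compound 4 (0.25 log units; within the scatter) gives the first direct comparison of the two ring sizes on this amide-type nitrogen, and it does not separate cyclohexyl from cyclopentyl. Two further exchanges at the same nitrogen also stay inside the scatter: a 1.0-fold higher number from compound 1 to compound 4 (0.02 log units; within the scatter) with cyclohexyl in place of cyclohexylmethyl, and a 1.5-fold higher number from compound 2 to compound 4 (0.19 log units; within the scatter) with hydrogen in place of cyclohexyl, so neither the extra carbon link nor the second cyclohexyl can be told apart here. No independent data bear on why these numbers sit so close.

As far as these compounds go, it remains open whether a non-carbocyclic group here, such as a phenyl ring, or a cyclohexyl carrying an amine or a carboxylic acid, would move the number beyond the scatter. From the compounds shown here alone, a small methyl group on this nitrogen is equally open.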